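Removing a Phenyl Ring from an Ether Side Chain

The source may hold more compounds than are shown below. What is called first, only, known or untested is meant among the compounds shown, and "the series" means these compounds.

This series shares a common core carrying a four-carbon chain that ends in an ether or amine. Compound 1 has the structure `CCc1nc2ccccc2n1CCCCOCc1ccccc1`. In an ADME assay on Vero cells (Chlorocebus sabaeus) for cytotoxicity, read by luminescence, with a stated time of 2 days (a lower number here means that less compound is tolerated, a higher number that more compound is tolerated), compound 1 gives 32 uM. Compound 3, with the structure `CCc1nc2ccc(C)cc2n1CCCCNc1ccc(C)cc1`, gives 20 uM in this assay. The two numbers lie within the usual scatter of each other, so neither can be said to be tolerated better than the other. Compound 2, with the structure `Clc1nc2ccccc2n1CCCCOc1ccccc1`, has "not determined" (no result reported) in this assay, and so adds nothing to the comparison.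

Compound 4 has the structure `CCc1nc2ccccc2n1CCCCOC`. It differs from compound 1 by a single change: hydrogen in place of phenyl on a saturated chain carbon bound to an oxygen on a saturated carbon. Among the compounds with values here, no measured pair in this set shows what such a change does, so the expectation rests only on the size of the change and on the closeness of the two numbers already seen. The step from compound 1 is expected to be small, a 1.4-fold higher number from compound 1 to compound 4 (0.15 log units; within the scatter), most likely within the scatter or a little upward rather than downward. Compound 4 is therefore estimated to give about 45 uM in this assay, with a range from 20 uM to 100 uM.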

Compound 4, half-maximal toxic concentration: > 50 uM
Compound 4: no number, only a limit; the forecaster's own chance of this, stated with the estimate: 20%; middle value at least 1.1-fold (0.04 log units) away from the limit.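

In this assay compound 4 gives > 50 uM, which is a limit of the assay and not a number. Cutting the side chain's end from benzyl to methyl gives the first comparison in this set between compounds that differ in one place, and it reads as an at least 1.5-fold higher number from compound 1 to compound 4 (0.19 log units; that floor lies within the scatter), so nothing in this pair points to less compound being tolerated once the phenyl ring has gone. The full size of the step cannot be read, because the value for compound 4 is cut off: the limit of > 50 uM in this assay, at which 1 of the 4 values shown sits.

The compounds shown leave open what happens between these two ends at this place, where an ethyl group, a propyl group or a longer chain could take the place of methyl or benzyl, and where a hydroxyl group or a carboxylic acid at the chain's end would be a different kind of change. Within the data shown here, they also leave open whether the same exchange of phenyl for hydrogen would read the same way on a core carrying other groups, since only this one pair bears on it.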